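The source may report more compounds than this note shows. Statements on the series, on what has been measured and on what is new or still open speak of the compounds shown alone.

The measured compounds:
compound 1, `C/N=C(/S)C1(c2cccnc2)CCCC/C1=C\C#N`, 10000 nM;
compound 2, `C/N=C(/S)[C@@]1(c2cccnc2)CCCC[C@@H]1CCN`, 10000 nM;
compound 3, `C/N=C(/S)[C@@]1(c2cccnc2)CCCC[C@@H]1C/C=C/c1ccc(F)cc1`, 10 nM.

In a functional assay (aorta) with Rattus norvegicus as the target (on this read-out lower numbers stand for stronger inhibition and higher numbers for weaker inhibition), compound 2 gives 10000 nM. That number is level with the number of compound 1 at the digits shown, and together these two stand as the highest of the three. Going by the values given here, compound 3, which gives 10 nM, is the one furthest from compound 2, its number lying lower by a margin well beyond the usual scatter.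

Compound 4, `C/N=C(/NCC[C@H]1CCCC[C@@]1(/C(S)=N\C)c1cccnc1)NS(C)(=O)=O`, has not yet been measured in this assay. It differs from compound 2 in one place: a group of 8 heavy atoms (3 carbon, 2 nitrogen, 2 oxygen, 1 sulfur; no ring) in place of a hydrogen atom, on an amine nitrogen. Among the compounds with values here, no step between measured compounds carries this change, so there is no direct precedent for its effect. Within the data shown here, the only guidance is that compound 3, the most elaborated of the three measured compounds, shows by far the lowest number, whereas the smaller compounds 1 and 2 share the highest one; this is a single comparison, not a rule.

On that basis compound 4 is expected to give a modestly lower number than its parent, estimated at 3000 nM, with a range from 300 nM to 10000 nM. The expected step is a 3.3-fold lower number from compound 2 to compound 4 (0.52 log units; beyond the scatter), a lowering that may not exceed the scatter.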

Compound 4, concentration for 90% inhibition: 30 nM
Beside the measured number, compound 4's estimate is 100-fold (2.00 log units) above it; the measured number lies below the stated range.
By their numbers in this assay, from the lowest: compound 3; then compound 4; then compounds 1 and 2 (each within the scatter of the next).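

In this assay, the amine nitrogen proves to be a place where a single change can shift the number greatly: replacing a hydrogen atom there with the group of 8 heavy atoms gives a 330-fold lower number from compound 2 to compound 4 (2.52 log units; beyond the scatter). The earlier compounds shown here offered no step at this nitrogen, so the 10000 nM of compound 2 did not reveal how much room for change this position held, and the new step shows that a group without a ring is enough here to move the number far beyond the scatter. Nothing among the data given explains why this change has so large an effect.

With only one group shown on this nitrogen, the compounds leave open which part of it carries the change, and whether a methyl group, an acetyl group or a methylsulfonyl group alone on the amine nitrogen would lower the number to any similar degree. They also leave open whether a longer chain between the amine nitrogen and the sulfonyl part, or a carboxylic acid in place of that part, would keep such a low number.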